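Proline acyl variation in a Wnt-3 antagonist series

The source may report more compounds than this note shows. Statements on the series, on what has been measured and on what is new or still open speak of the compounds shown alone.

Measured compounds:
compound 1 `CC(=O)N1CCC[C@H]1C(=O)N1CCC(NS(=O)(=O)c2cc(S(=O)(=O)c3ccccc3)ccc2C(F)(F)F)CC1`: 250 nM
compound 2 `CC(C)(C)CC(=O)N1CCC[C@H]1C(=O)N1CCC(NS(=O)(=O)c2cc(S(=O)(=O)c3ccccc3)ccc2C(F)(F)F)CC1`: 120 nM
compound 3 `CN(C)CC(=O)N1CCC[C@H]1C(=O)N1CCC(NS(=O)(=O)c2cc(S(=O)(=O)c3ccccc3)ccc2C(F)(F)F)CC1`: 310 nM

The three measured compounds share one core and differ only in the group on the carbonyl carbon bound to the amide-type ring nitrogen. In a functional assay on U2OS cells for antagonist activity at proto-oncogene Wnt-3 (Homo sapiens), read by a luciferase reporter, with a stated time of 18 h (a lower number here means that less compound is needed, a higher number that more compound is needed for the effect), compound 3 gives 310 nM, the highest of the three numbers; the step of a 1.2-fold higher number from compound 1 to compound 3 (0.09 log units; within the scatter) is within the scatter, whereas a 2.6-fold higher number from compound 2 to compound 3 (0.41 log units; beyond the scatter) lies beyond it. Compound 4 `O=C([C@@H]1CCCN1C(=O)c1ccncc1)N1CCC(NS(=O)(=O)c2cc(S(=O)(=O)c3ccccc3)ccc2C(F)(F)F)CC1` carries the change (pyridin-4-yl in place of (dimethylamino)methyl on a carbonyl carbon). Among the compounds with values here, no measured step exchanges an open chain for an aromatic ring at this carbonyl, so the comparison is indirect: a 2.1-fold lower number from compound 1 to compound 2 (0.32 log units; beyond the scatter) shows a modestly lower number on enlarging the group, and a 2.6-fold higher number from compound 2 to compound 3 (0.41 log units; beyond the scatter) a modestly higher one on moving to the dimethylamino chain. All three numbers sit close together, so only a small step is expected for compound 4 in this assay, estimated as a 1.6-fold lower number from compound 3 to compound 4 (0.19 log units; within the scatter). The estimate for compound 4 is 200 nM, expected between 70 nM and 600 nM.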

Compound 4, half-maximal effective concentration: 350 nM
Compound 4: the middle estimate sits 1.8-fold (0.24 log units) below what was measured; the measured number falls inside the stated range.
By their numbers in this assay, from the lowest: compound 2; then compounds 1, 3 and 4 (each within the scatter of the next).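

In this assay, the carbonyl carbon bound to the amide-type ring nitrogen carries an aromatic ring with no separation from the smaller groups: pyridin-4-yl in place of (dimethylamino)methyl gives a 1.1-fold higher number from compound 3 to compound 4 (0.05 log units; within the scatter) and pyridin-4-yl in place of methyl gives a 1.4-fold higher number from compound 1 to compound 4 (0.15 log units; within the scatter) as well. Neopentyl alone stands apart, as pyridin-4-yl in its place gives a 2.9-fold higher number from compound 2 to compound 4 (0.46 log units; beyond the scatter) and every step beyond the scatter in this set involves compound 2. No measurement here offers a reason for this pattern.

Open at this carbonyl carbon are a phenyl ring and pyridin-3-yl, which would show whether the ring nitrogen of pyridin-4-yl matters. Also open, on these data alone, are a cyclohexyl ring and a longer branched chain, which would show whether the lower number of compound 2 is tied to its open chain.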